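The compounds below may be only part of what the source reports. "The series", "measured", "known", "first", "only" and "open" are said of these compounds alone.

Measured so far:
Compound 1 `C/C(C(=O)NC1CC1)=C(/C)c1ccc(Cl)cc1` gives 150 mg/kg in a toxicity assay on the whole organism (strain Icem-CET (SPF Caw)) for cytotoxicity, with Mus musculus as the target; a higher number here means that more compound is needed for the effect, a lower number that less compound is needed.
Compound 2 `C=CCNC(=O)/C(C)=C(\C)c1cc(OC)c(OC)c(OC)c1` gives 190 mg/kg in this assay.

Going by the values given here, compound 1 has the lowest of the two numbers, but the only neighbour, compound 2, lies within the scatter of it, so the two values cannot be told apart. Compound 1 and compound 2 also differ in several places at once, so nothing can be read from that pair about any single change.

Compound 3 `C/C(C(=O)NC1CC1)=C(/C)c1ccc(C)cc1` has not yet been tested. It differs from compound 1 in one place: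
methyl in place of chloro on an aromatic carbon
Both groups are single heavy atoms without ring, donor, acceptor or charge, sitting on the same aromatic carbon. Among the compounds with values here, no measured pair shows what such a swap does here, so the safest expectation is a step in this assay of no size beyond the scatter, in either direction. For compound 3 the expected value in this assay is 170 mg/kg, with a range from 85 mg/kg to 340 mg/kg. This estimate means a step of a 1.1-fold higher number from compound 1 to compound 3 (0.05 log units; within the scatter) that stays within the usual scatter.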

Compound 3, dose for half-maximal effect: 150 mg/kg
The estimate for compound 3 lay 1.1-fold (0.05 log units) above the measured number, within the range that was stated.
By their numbers in this assay, from the lowest: compounds 1, 3 and 2 (each within the scatter of the next).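

Going by these compounds alone, compound 1 and compound 3 are the only pair here that differ in one place, so this is the one change that can be read on its own. In this assay, methyl in place of chloro on an aromatic carbon, para to a large group, gives no change at the digits printed from compound 1 to compound 3 (within the scatter). At this position, then, one group of a single heavy atom, with no ring, donor, acceptor or charge, can replace another of that kind without a step that stands out from the scatter, and no further measurement on these two groups is at hand to explain the result.

Both groups hold a single heavy atom, so this pair says nothing about a longer chain such as butyl, an amine or a carboxylic acid on the same aromatic carbon. From the compounds shown here alone, whether the number in this assay would hold with such groups or move beyond the scatter in either direction remains open, as does whether the same swap would behave alike on a core with other groups, such as that of compound 2.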